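A few compounds are considered here, and "the series" means these few. Any claim that something is new, unique, unknown or untested is made for them only; others in the source may bear on it.

Compound 1 `O=C(c1ccc(OCCCN2CC[C@H](NS(=O)(=O)c3ccc(Br)cc3)C2)cc1)C1CC1` gives 290 nM in an assay on isolated protein for binding affinity to histamine H2 receptor (Homo sapiens) (a higher number here means a weaker inhibitor, a lower number a stronger inhibitor), the lowest of the three numbers recorded so far. Compound 3 `CC(=O)c1ccc(OCCCN2CC[C@H](NC(=O)c3ccc(C#N)cc3)C2)cc1` gives 6100 nM and compound 2 `CC(=O)c1ccc(OCCCN2CC[C@H](NC(=O)[C@@H](N)CO)C2)cc1` gives 22000 nM, both well above compound 1. Among the measured compounds shown here, the single measured step, a 3.6-fold lower number from compound 2 to compound 3 (0.56 log units; beyond the scatter), concerns the group on the carbonyl carbon, not the halogen on the sulfonyl-bearing ring, so it does not bear directly on the change at hand. Compound 4 `O=C(c1ccc(OCCCN2CC[C@H](NS(=O)(=O)c3ccc(Cl)cc3)C2)cc1)C1CC1` differs from compound 1 by chloro in place of bromo on an aromatic carbon. For the measured compounds named here, no measured pair isolates a bromo-to-chloro exchange, so no step beyond the scatter is expected from compound 1 to compound 4. Compound 4 is therefore estimated at 350 nM, with a range of 150 nM to 900 nM. This expectation corresponds to a step of a 1.2-fold higher number from compound 1 to compound 4 (0.08 log units; within the scatter).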

Compound 4, inhibition constant: 290 nM
For compound 4 the middle estimate is 1.2-fold (0.08 log units) above the measured one; the measured number falls inside the stated range.
By their numbers in this assay, from the lowest: compounds 1 and 4 (each within the scatter of the next); then compound 3; then compound 2.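

In this assay, among the compounds shown here, the bromo-to-chloro exchange gives no change at the digits printed from compound 1 to compound 4 (within the scatter) as the first reading at this position, on an aromatic carbon para to a large group. On the core of compound 1, the two halogens are therefore interchangeable within the scatter. Nothing available explains this result.

Still open, from the compounds shown here alone, is whether a non-halogen group at this position, such as an amine, a carboxylic acid or a methoxy group, would shift the number. Also open, going by these compounds, is whether fluoro or iodo would match chloro and bromo.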